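Swapping a chained amine for a ring amine: clearance outlook

A few compounds are considered here, and "the series" means these few. Any claim that something is new, unique, unknown or untested is made for them only; others in the source may bear on it.

Compound 1, `Nc1nc(C(F)(F)F)cc2c1[nH]c(=O)n2Cc1ccc(NCCO)nc1`, gives < 8 mL.min-1.g-1 in an in vitro ADME assay on microsomes from liver (Homo sapiens) for pharmacokinetics; on this read-out higher numbers stand for fast clearance and lower numbers for slow clearance; this is a limit of the assay, not a number.
Compound 2, `Nc1nc(C(F)(F)F)cc2c1[nH]c(=O)n2Cc1ccc(NCCN2CCCC2)nc1`, gives 8.5 mL.min-1.g-1 in this assay.
Compound 3, `CN1CCN(CCN(C)c2ccc(Cn3c(=O)[nH]c4c(N)nc(C(F)(F)F)cc43)cn2)CC1`, gives 25 mL.min-1.g-1 in this assay.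

Of the two numbers shown, compound 2 holds the lower one, with one neighbour above it: a 2.9-fold higher number from compound 2 to compound 3 (0.47 log units; beyond the scatter). A third value is only a limit: the limit of < 8 mL.min-1.g-1 in this assay, at which 1 of the 3 values shown sits.

Compound 4, `CN1CCN(c2ccc(Cn3c(=O)[nH]c4c(N)nc(C(F)(F)F)cc43)cn2)CC1`, differs from compound 2 in a single place: 4-methylpiperazin-1-yl in place of (2-(pyrrolidin-1-yl)ethyl)amino on an aromatic carbon.

Among the compounds with values here, two measured steps bear on this. The exchange of one amine-bearing chain for another was within the scatter: an at least 1.0-fold higher number from compound 1 to compound 2 (0.02 log units; that floor lies within the scatter). Bringing in the 4-methylpiperazin-1-yl group on a chain raised the number modestly: a 2.9-fold higher number from compound 2 to compound 3 (0.47 log units; beyond the scatter) and an at least 3.1-fold higher number from compound 1 to compound 3 (0.49 log units; beyond the scatter). Here the same ring enters without a chain, so a modest rise in this assay is expected, in the same direction, but smaller than the step to compound 3.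

For compound 4 the expected value in this assay is 14 mL.min-1.g-1, between 6 mL.min-1.g-1 and 30 mL.min-1.g-1, which is expected to mean a 1.6-fold higher number from compound 2 to compound 4 (0.22 log units; within the scatter).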

Compound 4, intrinsic clearance in microsomes: 30 mL.min-1.g-1
Beside the measured number, compound 4's estimate is 2.1-fold (0.33 log units) below it; low and high end bracket the measured number.
By their numbers in this assay, from the lowest: compound 2; then compounds 3 and 4 (each within the scatter of the next). At a limit, below all of these: compound 1.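

In this assay the 4-methylpiperazin-1-yl ring, set directly on the aromatic carbon next to the ring nitrogen, still gives a 3.5-fold higher number from compound 2 to compound 4 (0.55 log units; beyond the scatter) without any chain to carry it. Compound 3 holds the same ring on a chain, yet a 1.2-fold higher number from compound 3 to compound 4 (0.08 log units; within the scatter) is all that separates the two forms, so the chain makes no difference that can be read here. Compound 1 stands at a limit of the assay, not a number, so an at least 3.7-fold higher number from compound 1 to compound 4 (0.57 log units; beyond the scatter) is only a floor and the true step may be larger.

Still open, from the compounds shown here alone, is whether a morpholine, an unsubstituted piperazine or a pyrrolidine set directly on this carbon would behave like 4-methylpiperazin-1-yl. Nothing shown here accounts for the higher numbers of compound 3 and compound 4.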